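The source may hold more compounds than are shown below. What is called first, only, known or untested is meant among the compounds shown, and "the series" means these compounds.

Compound 3 `CCc1ccccc1-n1nncc1CN1C(=O)C2(C(C#N)=C(N)Oc3c(N)cc4nc5ccccc5nc4c32)c2ccccc21` is the only one of the three measured compounds that returns a number in a functional assay on HCT-116 cells (Homo sapiens) for antiproliferative activity, read by MTT assay, with a stated time of 48 h (on this read-out higher numbers stand for weaker inhibition and lower numbers for stronger inhibition), rather than a limit: compound 3 gives 10300 nM. Compound 1 `N#CC1=C(N)Oc2c(c3nc4ccccc4nc3c3ccccc23)C12C(=O)N(Cc1cnnn1-c1ccc(Cl)cc1)c1ccccc12` reaches only a limit in this assay, namely > 50000 nM. Compound 2 `CCOc1ccccc1-n1nncc1CN1C(=O)C2(C(C#N)=C(N)Oc3c2c2nc4ccccc4nc2c2ccccc32)c2ccccc21` likewise reaches only a limit in this assay, namely > 50000 nM. Compounds 1 and 2 differ in one place, a change of the aryl group on the triazole nitrogen, but the step that the two limits leave unreadable from compound 1 to compound 2 stays unreadable since both values sit at the limit of > 50000 nM in this assay, at which 2 of the 3 values shown sit.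

Compound 4 `COc1ccc(OC)c(-n2nncc2CN2C(=O)C3(C(C#N)=C(N)Oc4c(N)cc5nc6ccccc6nc5c43)c3ccccc32)c1` is made from compound 3 by a change of the same kind: 2,5-dimethoxyphenyl in place of 2-ethylphenyl on an aromatic nitrogen. Among the measured compounds shown here, the only measured step of this kind, from compound 1 to compound 2, gives no readable size, so no measured step bears usefully on the change from compound 3 to compound 4. The expected step of a 1.2-fold higher number from compound 3 to compound 4 (0.07 log units; within the scatter) is therefore one within the usual scatter, in no particular direction. Compound 4 is estimated to give 12000 nM in this assay, with a range from 4000 nM to 40000 nM.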

Compound 4, half-maximal inhibitory concentration: > 50000 nM
Compound 4 ended at the assay's limit; the forecaster's own chance of this, stated with the estimate: 25%; middle value at least 4.1-fold (0.61 log units) away from the limit.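

In this assay, replacing 2-ethylphenyl with 2,5-dimethoxyphenyl on the aromatic nitrogen gives an at least 4.8-fold higher number from compound 3 to compound 4 (0.68 log units; beyond the scatter). Among the compounds shown here, this is the first change at this position with a readable direction, and it shows that the aryl group here can shift the result on this core by more than the usual scatter. Only a lower bound on the size of the step can be given, because compound 4 ended at a limit: the limit of > 50000 nM in this assay, at which 3 of the 4 values shown sit.

Which of the two methoxy groups in 2,5-dimethoxyphenyl accounts for the step stays open, and a 2-methoxyphenyl group at this position would speak to that. Also open, from the compounds shown here alone, is how a plain phenyl or a 4-aminophenyl group on this nitrogen would compare with the 2-ethylphenyl group of compound 3.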